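Inverting One Ring Stereocentre of Compound 3

A few compounds are considered here, and "the series" means these few. Any claim that something is new, unique, unknown or untested is made for them only; others in the source may bear on it.

Of the compounds shown here, three have been measured in a functional assay on N2a cells (Mus musculus), with a stated time of 48 h, tested at 0.01 uM; on this read-out lower numbers stand for a weaker effect and higher numbers for a stronger effect at the one concentration tested. Compound 1 `C#CC[C@H]1C[C@H](n2cccc2C(C)=O)C(=O)O1` gives 9.04% in this assay. Compound 2 `C#CC[C@@H]1C[C@H](n2cccc2C(=O)C(F)(F)F)C(=O)O1` gives 33.7% in this assay. Compound 3 `CC(=O)c1cccn1[C@H]1C[C@@H](Cc2cn(Cc3ccccc3)nn2)OC1=O` gives 5.41% in this assay, the lowest of the three numbers; its nearest neighbour is compound 1, whose number sits higher but within the scatter, while compound 2 lies furthest away, higher by an amount beyond the scatter. Compound 4 `CC(=O)c1cccn1[C@H]1C[C@H](Cc2cn(Cc3ccccc3)nn2)OC1=O` has not yet been measured. It differs from compound 3 as follows: the two compounds have the same atoms and bonds and differ only in configuration as drawn: 1 of 2 stereo elements differ; a stereocentre at a saturated ring carbon is drawn S in compound 3 and R in compound 4. No pair of measured compounds differing in a single place is available, so there is no measured step to lean on, and nothing among these three compounds tells how a change of configuration at that ring carbon shows up in this assay. This step is therefore expected to be small, a number 4.6 percentage points higher from compound 3 to compound 4 (within the scatter), with no firm direction and possibly not beyond the scatter. Compound 4 is estimated at 10%, within a range from 2% to 30%.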

Compound 4, a percentage reported as activity, at one concentration (the size of the read-out at that concentration, not a potency): -2.23%
The estimate for compound 4 lay 12.2 percentage points above the measured number; the measured number lies below the stated range.
By their numbers in this assay, from the lowest: compounds 4, 3 and 1 (each within the scatter of the next, the first and the last beyond it); then compound 2.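

In this assay, going by these compounds alone, the inversion of this saturated ring carbon from S to R gives a number 7.6 percentage points lower from compound 3 to compound 4 (within the scatter), the only measured step in this set between compounds that differ in one place. The earlier compounds shown here could say nothing about configuration at this position, whereas this pair isolates it, as the atoms, the bonds and the other stereo element stay the same: the fact that compounds 3 and 4 differ only in the configuration as drawn. At the one concentration tested, the change from S to R at this carbon therefore produces no difference that can be told from the scatter.

From the compounds shown here alone, whether the two configurations would separate at other concentrations remains open. Going by these compounds, it is also open whether the inversion would read the same way on a core carrying another group, such as an amine or a carboxylic acid, in place of the present side chain.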